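The compounds below may be only part of what the source reports. "The series", "measured", "known", "first", "only" and "open" are said of these compounds alone.

Working notes on the series, read in a functional assay on the whole organism for inhibition, with Lemna aequinoctialis as the target, with a stated time of 7 days, tested at 5 ug/mL; a higher number here means more inhibition of growth at the concentration tested, a lower number less inhibition of growth. Compound 1 (`O=C1Nc2ccc(F)cc2/C1=N/NC(=S)Nc1ccccc1`) gives 10% and compound 2 (`O=C1Nc2ccc(F)cc2/C1=N/NC(=S)Nc1c(F)cccc1F`) gives 0%. These two values lie within the scatter of each other, so compound 2 stands level with compound 1 and shows little inhibition of growth at the concentration tested.

Compound 3 (`O=C1Nc2ccc(F)cc2/C1=N/NC(=S)Nc1cc(F)cc(F)c1`) has not yet been measured. It carries 3,5-difluorophenyl in place of 2,6-difluorophenyl on an amide-type nitrogen, with the shared core unchanged: 3,5-difluorophenyl in place of 2,6-difluorophenyl on an amide-type nitrogen.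

Among the measured compounds shown here, only one measured step bears on this place, a number 10 percentage points lower from compound 1 to compound 2 (within the scatter). That step is the exchange of phenyl for 2,6-difluorophenyl on the same nitrogen. For the measured compounds named here, no measured compound carries 3,5-difluorophenyl, so the data give no direct reading of this arrangement. The small size of that one step gives no ground for expecting a large change, and any direction is only weakly supported.

The expected change is a number 5 percentage points higher from compound 2 to compound 3 (within the scatter), no step beyond the scatter. Compound 3 is estimated at 5%, with an expected range from 0% to 20%.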

Compound 3, percent growth inhibition at one concentration: 0%
Beside the measured number, compound 3's estimate is 5 percentage points above it; low and high end bracket the measured number.
By their numbers in this assay, from the lowest: compounds 2, 3 and 1 (each within the scatter of the next).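

Among the compounds shown here, on the amide-type nitrogen whose other neighbour is the thiocarbonyl carbon, 3,5-difluorophenyl in place of 2,6-difluorophenyl gives no change at the digits printed from compound 2 to compound 3 (within the scatter) in this assay and so offers the first reading of two groups with the same atoms joined differently; at the concentration tested, this difference does not separate the two compounds. Against phenyl, the newly placed difluorophenyl group gives a number 10 percentage points lower from compound 1 to compound 3 (within the scatter) and, like 2,6-difluorophenyl, does not stand apart from phenyl, so all three compounds show little inhibition of growth at the concentration tested. No supporting measurement is available to explain these readings.

Still open is whether any group on this nitrogen can give a reading clear of the scatter, as the compounds shown carry only phenyl and the two difluorophenyl groups there. A phenyl ring bearing an amine or a carboxylic acid, or a longer chain such as benzyl on the same nitrogen, would show whether this position can move the growth inhibition at all.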